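Chloro for methoxy, repeated across two cores

The source may hold more compounds than are shown below. What is called first, only, known or untested is meant among the compounds shown, and "the series" means these compounds.

Compound 1 `COc1ccccc1N1CCN(CCCCn2nc(-n3cnc4ccccc43)ccc2=O)CC1` gives 1.1 nM in an assay on cell membranes from brain for binding affinity to Adrenergic receptor alpha-1 (Rattus norvegicus), read by radioligand binding; on this read-out lower numbers stand for stronger inhibition and higher numbers for weaker inhibition. Compound 2 `O=c1ccc(-n2cnc3ccccc32)nn1CCCCN1CCN(c2ccccc2Cl)CC1` gives 1.3 nM in this assay; the structural difference between the two is chloro in place of methoxy on an aromatic carbon, and the step is a 1.2-fold higher number from compound 1 to compound 2 (0.07 log units; within the scatter). Compound 3 `COc1ccccc1N1CCN(CCCCn2nc(-n3ccnc3)ccc2=O)CC1` gives 47.5 nM in this assay; it differs from compound 1 in the core, (1H-imidazol-1-yl in place of 1H-benzimidazol-1-yl on an aromatic carbon), and the step is a 43-fold higher number from compound 1 to compound 3 (1.64 log units; beyond the scatter). Compound 3 thus holds the highest number of the three measured, well apart from both others.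

Compound 4 `O=c1ccc(-n2ccnc2)nn1CCCCN1CCN(c2ccccc2Cl)CC1` has not yet been measured in this assay. It differs from compound 3 by chloro in place of methoxy on an aromatic carbon. The place is described in the same words as for the pair from compound 1 to compound 2, so this is the same change, now carried out on the core of compound 3 rather than on that of compound 1. Whether the change behaves alike on the two cores is not shown by any further pair; the expectation rests on a single earlier occurrence.

For compound 4 the step is expected to be a 1.2-fold higher number from compound 3 to compound 4 (0.06 log units; within the scatter), about as small as the earlier one, because a 1.2-fold higher number from compound 1 to compound 2 (0.07 log units; within the scatter) stayed within the scatter. Compound 4 is therefore estimated at 55 nM in this assay, with a range from 25 nM to 120 nM that allows for the change acting somewhat differently on the core of compound 3.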

Compound 4, inhibition constant: 24.6 nM
Compound 4: the middle estimate sits 2.2-fold (0.35 log units) above what was measured, outside the stated range (below it).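

In this assay, chloro in place of methoxy on the second core gives a 1.9-fold lower number from compound 3 to compound 4 (0.29 log units; within the scatter), so the change stays within the scatter on both cores, and the two steps do not differ: the same change on two cores in this assay, a 1.2-fold higher number (0.07 log units; within the scatter) from compound 1 to compound 2 and a 1.9-fold lower number (0.29 log units; within the scatter) from compound 3 to compound 4, 2.3-fold (0.36 log units) apart, within the scatter of two such steps. Read the other way, 1H-imidazol-1-yl in place of 1H-benzimidazol-1-yl with chloro already in place gives a 19-fold higher number from compound 2 to compound 4 (1.28 log units; beyond the scatter), again a large step, and it agrees with the step seen with methoxy in place: the same change on two cores in this assay, a 43-fold higher number (1.64 log units; beyond the scatter) from compound 1 to compound 3 and a 19-fold higher number (1.28 log units; beyond the scatter) from compound 2 to compound 4, 2.3-fold (0.36 log units) apart, within the scatter of two such steps. Across these four compounds the two changes combine with no difference beyond the scatter, but this rests on only two pairs per change, says nothing about any other core, and gives no ground for reading the opposite directions of the two chloro steps as real.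

Left open is whether fluoro or methyl in place of chloro on the 2-chlorophenyl group would leave the number unchanged, and whether a shorter or longer chain than the one shared by all four compounds would shift it. Also open, as far as these compounds go, is whether another group in place of 1H-benzimidazol-1-yl, such as an amine or a phenyl group, would fall nearer to compound 1 or to compound 3.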